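Swapping a piperidine for a piperazine on the amine chain

The compounds below may be only part of what the source reports. "The series", "measured", "known", "first", "only" and "open" are said of these compounds alone.

Compound 1 `CN(C)CCn1c2ccc3ccccc3c2c2nc3ccccc3nc21`: 49900 nM
Compound 2 `CCCN(CCC)CCn1c2ccc3ccccc3c2c2nc3ccccc3nc21`: a limit, > 42600 nM
Compound 3 `CC1CCN(CCn2c3ccc4ccccc4c3c3nc4ccccc4nc32)CC1`: a limit, > 214000 nM

In an ADME assay on L929 cells (Mus musculus) for cytotoxicity (on this read-out higher numbers stand for lower toxicity in this test and lower numbers for higher toxicity in this test), compound 1 gives 49900 nM. For compound 3 only a limit is known, > 214000 nM. Compound 3 thus sits at the limit of > 214000 nM in this assay, at which 1 of the 3 values shown sits, and one further value is also a limit. Compound 4 `CN1CCN(CCn2c3ccc4ccccc4c3c3nc4ccccc4nc32)CC1` differs from compound 3 by 4-methylpiperazin-1-yl in place of 4-methylpiperidin-1-yl on a saturated chain carbon, two bonds along the chain from an aromatic nitrogen. Among the measured compounds shown here, no measured step exchanges these two rings; the only readable step touching compound 3 is an at least 4.2-fold higher number from compound 1 to compound 3 (0.63 log units; beyond the scatter), while a step that the limit leaves unreadable from compound 1 to compound 2 and a step that the two limits leave unreadable from compound 2 to compound 3 cannot be sized. Compound 4 is therefore expected to show a step of an at least 1.1-fold lower number from compound 3 to compound 4 (0.07 log units; that floor lies within the scatter), within the scatter. Compound 4 is estimated at 180000 nM, between 50000 nM and 600000 nM.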

Compound 4, half-maximal cytotoxic concentration: 21400 nM
Beside the measured number, compound 4's estimate is 8.4-fold (0.92 log units) above it; the measured number lies below the stated range.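

At this place on the chain, a ring swap alone moves the number in this assay: it gives an at least 10-fold lower number from compound 3 to compound 4 (1.00 log units; beyond the scatter), a floor set by the limit for compound 3, so the lower number, meaning higher toxicity in this test, goes with one ring carbon becoming nitrogen. There is also a 2.3-fold lower number from compound 1 to compound 4 (0.37 log units; beyond the scatter), so a ring here does not by itself raise the number, as compound 3 alone suggested. The remaining step, an at least 1.9-fold lower number from compound 2 to compound 4 (0.29 log units; that floor lies within the scatter), rests on a limit for compound 2: the limit of > 42600 nM in this assay, at which 1 of the 4 values shown sits.

Still open, on these data alone, is how a morpholin-4-yl group or a piperazin-1-yl group without the methyl would read at this place. A longer chain is equally untested among the compounds shown.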